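The compounds below may be only part of what the source reports. "The series", "measured", "known", "first", "only" and "open" are said of these compounds alone.

Measured in an ADME assay on microsomes from liver (Rattus norvegicus) for metabolic stability, read by LC-MS, using NADPH, at 37 degrees C; a lower number here means that the compound disappears faster, a higher number that the compound lasts longer:
Compound 1 `Cc1ccccc1-c1nc(CN2CCC(C(=O)NCCCN3CC(C)(C)CC(C)(C)C3)CC2)c(C)o1`: 0.095 h
Compound 2 `Cc1ccccc1-c1nc(CN2CCC(C(=O)NCCCN3CCC(C)(C)CC3)CC2)c(C)o1`: > 0.5 h
Compound 3 `Cc1ccccc1-c1nc(CN2CCC(C(=O)NCCCN3CC4CCCC(C4)C3)CC2)c(C)o1`: 0.123 h

The entry for compound 2, > 0.5 h, is a limit of the assay and not a number.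

Compound 3 stands level with compound 1, the measurements showing a 1.3-fold higher number from compound 1 to compound 3 (0.11 log units; within the scatter). Compound 2 stands apart from both, with an at least 5.2-fold higher number from compound 1 to compound 2 (0.72 log units; beyond the scatter) and an at least 4.0-fold lower number from compound 2 to compound 3 (0.60 log units; beyond the scatter). For the measured compounds named here, in both of these steps the smaller group is the one carried by compound 2.

The change to compound 4 `Cc1ccccc1-c1nc(CN2CCC(C(=O)NCCCCN3C[C@H](C)C[C@H](C)C3)CC2)c(C)o1` is a group of 9 heavy atoms (8 carbon, 1 nitrogen; one six-membered non-aromatic ring with 1 hetero atom) in place of a group of 9 heavy atoms (8 carbon, 1 nitrogen; one six-membered non-aromatic ring of carbon only, one six-membered non-aromatic ring with 1 hetero atom), on a saturated chain carbon, three bonds along the chain from an amide-type nitrogen, and the group that enters is (3,5-dimethylpiperidin-1-yl)methyl. The heavy-atom count stays the same, so compound 4 is expected to follow compound 3 at 0.123 h, with no step beyond the scatter in this assay. For compound 4 the expected change is a 1.1-fold higher number from compound 3 to compound 4 (0.06 log units; within the scatter). For compound 4 the estimate is 0.14 h, with an expected range from 0.06 h to 0.35 h.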

Compound 4, half-life: 0.2 h
Beside the measured number, compound 4's estimate is 1.4-fold (0.15 log units) below it; measured number inside the range.
By their numbers in this assay, from the lowest: compounds 1, 3 and 4 (each within the scatter of the next, the first and the last beyond it). At a limit, above all of these: compound 2.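

In this assay, the (3,5-dimethylpiperidin-1-yl)methyl group of compound 4 cannot be told apart from the group it replaces in compound 3, the step being a 1.6-fold higher number from compound 3 to compound 4 (0.21 log units; within the scatter) and so within the scatter. Against compound 1 the same group gives a 2.1-fold higher number from compound 1 to compound 4 (0.32 log units; beyond the scatter) and so a step beyond the scatter at this position that does not involve the 4,4-dimethylpiperidin-1-yl group of compound 2, the only group that stood apart until now. Compound 2 still stands apart, with an at least 2.5-fold lower number from compound 2 to compound 4 (0.39 log units; beyond the scatter), and its entry is a limit of the assay and not a number: the limit of > 0.5 h in this assay, at which 1 of the 4 values shown sits.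

The compounds shown do not separate the ring of (3,5-dimethylpiperidin-1-yl)methyl from the methylene link that comes with it. Going by these compounds, how a morpholine or a piperazine at this position would read in this assay remains open.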